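This account rests on a few compounds, and the source may have more. Where it says the series, first, only, none or still open, it means among the compounds named here.

Measured so far in an assay (Cavia porcellus) for inhibition of Polyunsaturated fatty acid 5-lipoxygenase (Homo sapiens); a lower number here means a stronger inhibitor, a higher number a weaker inhibitor:
- compound 1 `NC(=O)N(O)CC1=Cc2cc(OCC3CCCCC3)ccc2OC1` gives 1360 nM
- compound 2 `CC(C)(C)c1ccc(Oc2ccc3c(c2)C=C(CN(O)C(N)=O)CO3)cc1` gives 2400 nM
- compound 3 `NC(=S)N(O)CC1=Cc2cc(Oc3ccccc3)ccc2OC1` gives 180 nM

Compound 3 has the lowest number of the three in this assay; compound 1 stands a good way above it, compound 2 further still, both gaps beyond the usual scatter. Compound 4 `CC(C)NC(=O)N(O)CC1=Cc2cc(Oc3ccccc3)ccc2OC1` is not yet measured. It differs from compound 3 by a group of 6 heavy atoms (4 carbon, 1 nitrogen, 1 oxygen; no ring) in place of a group of 3 heavy atoms (1 carbon, 1 nitrogen, 1 sulfur; no ring), on an amine nitrogen. Within the data shown here, no pair among the measured compounds isolates this change, so the size of the step is uncertain; compound 1, which carries an unsubstituted carbamoyl group on a different core, sits well above compound 3, which points to a weakening of moderate size rather than none. Compound 4 is expected at 600 nM, within 150 nM to 2500 nM, so an estimated step of a 3.3-fold higher number from compound 3 to compound 4 (0.52 log units; beyond the scatter).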

Compound 4, half-maximal inhibitory concentration: 49 nM
Beside the measured number, compound 4's estimate is 12-fold (1.09 log units) above it; measured number outside the range, below it.
By their numbers in this assay, from the lowest: compound 4; then compound 3; then compounds 1 and 2 (each within the scatter of the next).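

In this assay the isopropylcarbamoyl group on this amine nitrogen, in place of the sulfur-bearing group, gives a 3.7-fold lower number from compound 3 to compound 4 (0.57 log units; beyond the scatter), so this position accepts a group of 6 heavy atoms without loss. The step combines two changes, sulfur to oxygen and the added isopropyl, and does not separate them. No measurement available here bears on the reason for this result.

Open, as far as these compounds go, is how much of the step belongs to each change. Also open, from the compounds shown here alone, is how a methyl, a longer chain or a cyclopropyl would read at this position on the shared core.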